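Swapping the ring-bearing tail on a chemokine receptor antagonist

The compounds below may be only part of what the source reports. "The series", "measured", "known", "first", "only" and "open" are said of these compounds alone.

Measured so far in a functional assay on cells for antagonist activity at C-X-C chemokine receptor type 4 (Homo sapiens), read by fluorescence and calcium flux, with stated times of 25 min and 90 s; a lower number here means a stronger inhibitor, a higher number a weaker inhibitor:
compound 1, `c1ccc2c(c1)CN[C@@H](CN(CCCCNCC1CCCCC1)[C@H]1CCCc3cccnc31)C2`, gives 158 nM;
compound 2, `c1ccc2c(c1)CN[C@@H](CN(CCCCNC1CCSCC1)[C@H]1CCCc3cccnc31)C2`, gives 54.7 nM.

Among the measured compounds shown here, compound 2 holds the lowest of the two numbers in this assay; its only neighbour is compound 1, and the single one-place change between them, a 2.9-fold lower number from compound 1 to compound 2 (0.46 log units; beyond the scatter), lies beyond the scatter. For the measured compounds named here, this is the sole measured step, and it shows that changing the ring-bearing tail on the amine nitrogen can move the number by a modest amount.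

Compound 3, `C(=C/CN(C[C@H]1Cc2ccccc2CN1)[C@H]1CCCc2cccnc21)\CNCC1CCOCC1`, has not yet been measured. Relative to compound 2 the change is a group of 11 heavy atoms (9 carbon, 1 nitrogen, 1 oxygen; one six-membered non-aromatic ring with 1 hetero atom) in place of a group of 10 heavy atoms (8 carbon, 1 nitrogen, 1 sulfur; one six-membered non-aromatic ring with 1 hetero atom), on a saturated chain carbon bound to an amine nitrogen. The incoming group again carries a six-membered non-aromatic ring with one hetero atom, now joined through a chain that holds a double bond, so the step from compound 1 to compound 2 bears on it only loosely. Going by the values given here, with one step of modest size as the only guide, compound 3 is expected to land close to compound 2, perhaps drifting back toward compound 1, and the step of a 1.8-fold higher number from compound 2 to compound 3 (0.26 log units; within the scatter) is estimated to stay near the edge of the scatter. For compound 3 the estimate is 100 nM, within a range from 35 nM to 300 nM.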

Compound 3, half-maximal inhibitory concentration: 24.2 nM
Estimate against measurement, compound 3: 4.1-fold (0.62 log units) above, and the stated range ends above it.
By their numbers in this assay, from the lowest: compound 3; then compound 2; then compound 1.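

Among the compounds shown here, the tail on this amine nitrogen can still be changed with gain: in this assay, there is a 2.3-fold lower number from compound 2 to compound 3 (0.35 log units; beyond the scatter), so the lowest number so far comes from a tail that holds a double bond outside aromatic rings and has oxygen, not sulfur, as the hetero atom of its six-membered ring. Measured against the all-carbon ring of compound 1, the same tail gives a 6.5-fold lower number from compound 1 to compound 3 (0.81 log units; beyond the scatter), a larger step than either earlier one, and both tails with a hetero atom in the ring, those of compound 2 and compound 3, sit below compound 1 in this small set. No measurement here explains why the number falls at this place.

The step from compound 2 to compound 3 changes the ring atom, the chain and the way the ring is joined all at once, so the three compounds cannot show how much each change contributes; a matching tail with a saturated chain and the same oxygen ring would be needed to separate them. Going by these compounds, how a piperidine ring, a carboxylic acid or a longer chain would fare at this place also stays open.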